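This account rests on a few compounds, and the source may have more. Where it says the series, first, only, none or still open, it means among the compounds named here.

For the measured compounds named here, in a functional assay on U-251 cells (Homo sapiens) for inhibition, read by MTT assay, with a stated time of 2 days (on this read-out higher numbers stand for weaker inhibition of growth and lower numbers for stronger inhibition of growth), two compounds have numbers so far. Compound 1 `Nc1ccccc1NC(=O)c1ccc(NCC(=O)Nc2ccc([N+](=O)[O-])cc2)cc1` gives 8200 nM, and compound 2 `Nc1ccccc1NC(=O)c1ccc(NCC(=O)Nc2cccc([N+](=O)[O-])c2)cc1` gives 13500 nM. These two values lie within the scatter of each other, so compound 2 stands level with compound 1 on the numbers shown.

The next compound, compound 3 `Cc1ccc(NC(=O)CNc2ccc(C(=O)Nc3ccccc3N)cc2)cc1`, departs from compound 2 at a single place: 4-methylphenyl in place of 3-nitrophenyl on an amide-type nitrogen. It carries 4-methylphenyl in place of 3-nitrophenyl on an amide-type nitrogen.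

Going by the values given here, only one measured step bears on this change, and only indirectly. The exchange of 4-nitrophenyl for 3-nitrophenyl at the same nitrogen gave a 1.6-fold higher number from compound 1 to compound 2 (0.22 log units; within the scatter). Both measured compounds carry a nitrophenyl group there, so the data do not show what a 4-methylphenyl group does. With no measured step beyond the scatter, no clear direction can be drawn, and the expectation stays close to the values of compound 1 and compound 2, with a wide margin.

The expected change is a 1.4-fold lower number from compound 2 to compound 3 (0.13 log units; within the scatter). Compound 3 is estimated at 10000 nM, with an expected range from 3500 nM to 28000 nM.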

Compound 3, concentration for 50% growth inhibition: 84000 nM
The estimate for compound 3 lay 8.4-fold (0.92 log units) below the measured number, and the stated range ends below it.
By their numbers in this assay, from the lowest: compounds 1 and 2 (each within the scatter of the next); then compound 3.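

Replacing the 3-nitrophenyl on the amide-type nitrogen with 4-methylphenyl gives, in this assay, a 6.2-fold higher number from compound 2 to compound 3 (0.79 log units; beyond the scatter) and, read against the other nitro compound, methyl in place of nitro on an aromatic carbon gives a 10-fold higher number from compound 1 to compound 3 (1.01 log units; beyond the scatter). The group on this nitrogen can therefore shift growth inhibition beyond the scatter, which the two nitrophenyl compounds alone did not show, and among the three compounds the weaker inhibition goes with the 4-methylphenyl group. No supporting measurement is available to explain why the change weakens inhibition.

The compounds shown leave open whether the weaker inhibition of compound 3 follows from losing the nitro group or from gaining the methyl group, since a plain phenyl ring on this nitrogen is not among them. They also leave open how this nitrogen's aromatic ring would fare with a different group in place of nitro or methyl, such as an amine, a nitrile or a carboxylic acid.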